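The source may report more compounds than this note shows. Statements on the series, on what has been measured and on what is new or still open speak of the compounds shown alone.

Measured so far:
Compound 1, `CN1CCC(c2cc(-c3cn(C(=O)NCCCCc4ccccc4)c(=O)o3)ccc2F)CC1`: 341 nM
Compound 2, `CCCCCNC(=O)n1cc(-c2ccc(F)c(C3CCN(C)CC3)c2)oc1=O`: 1920 nM
Compound 3, `CN1CCC(c2cc(F)ccc2-c2cn(C(=O)NCCCCc3ccccc3)c(=O)o2)CC1`: 337 nM

All three were tested in an assay on isolated protein for inhibition of acid ceramidase (Homo sapiens), read by LC-MS, with a stated time of 1 h; on this read-out lower numbers stand for stronger inhibition and higher numbers for weaker inhibition. Compound 1 and compound 2 share one core and differ by a single change, (methyl in place of phenyl on a saturated chain carbon, four bonds along the chain from an amide-type nitrogen). That change gave a 5.6-fold higher number from compound 1 to compound 2 (0.75 log units; beyond the scatter), a clear weakening.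

Compound 3 is built from the same atoms as compound 1, joined differently; the difference between the two cores is not broken down here. In this assay compound 3 gives 337 nM, and compound 1 gives 341 nM, so the two lie within the usual scatter of each other.

Compound 4, `CCCCCNC(=O)n1cc(-c2ccc(F)cc2C2CCN(C)CC2)oc1=O`, has not yet been measured. It stands to compound 3 as compound 2 stands to compound 1, by the same change, (methyl in place of phenyl on a saturated chain carbon, four bonds along the chain from an amide-type nitrogen), at the same place. Since the measured step of a 5.6-fold higher number from compound 1 to compound 2 (0.75 log units; beyond the scatter) was a modest weakening, a step of similar size is expected here, and the estimated step of a 5.6-fold higher number from compound 3 to compound 4 (0.75 log units; beyond the scatter) rests on that single precedent. Compound 4 is therefore expected to give about 1900 nM, with a likely range from 900 nM to 4000 nM.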

Compound 4, half-maximal inhibitory concentration: 129 nM
Estimate against measurement, compound 4: 15-fold (1.17 log units) above; the measured number lies below the stated range.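

In this assay, the change of phenyl to methyl on the core of compound 3 gave a 2.6-fold lower number from compound 3 to compound 4 (0.42 log units; beyond the scatter), and this does not match the step seen with the same change on the core of compound 1: the same change on two cores in this assay, a 5.6-fold higher number (0.75 log units; beyond the scatter) from compound 1 to compound 2 and a 2.6-fold lower number (0.42 log units; beyond the scatter) from compound 3 to compound 4, 15-fold (1.17 log units) apart, beyond the scatter of two such steps

Across these two pairs, the effect of the change therefore does not carry from one core to the other, and even its direction depends on the core that bears it. The two pairs do not show why the cores respond differently, and they give no rule for how the same change would behave on a further core.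

On these data alone, it remains open whether a shorter chain, a longer chain or a cyclohexyl ring in place of the phenyl would follow the pattern of the core of compound 1 or that of compound 3. As far as these compounds go, it is also open how either core would respond to an amine or a carboxylic acid on the chain.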